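Ester side-chain growth in the lactone series

A few compounds are considered here, and "the series" means these few. Any claim that something is new, unique, unknown or untested is made for them only; others in the source may bear on it.

Measured so far:
- compound 1 `CC(C)C(=O)O[C@H]1C[C@@H](C)C=C2C=C[C@H](C)[C@H](CC[C@@H]3C[C@@H](O)CC(=O)O3)C21`; in an assay for inhibition of 3-hydroxy-3-methylglutaryl-coenzyme A reductase (Rattus norvegicus) (on this read-out lower numbers stand for stronger inhibition and higher numbers for weaker inhibition), compound 1 gives 7.7 nM
- compound 2 `C[C@H]1C=C2C=C[C@H](C)[C@H](CC[C@@H]3C[C@@H](O)CC(=O)O3)C2[C@@H](OC(=O)C(C)(C)C)C1`; in this assay compound 2 gives 2.7 nM

Compound 2 holds the lower of the two numbers; the gap to compound 1 is beyond the scatter. Within the data shown here, the one measured step, a 2.9-fold lower number from compound 1 to compound 2 (0.46 log units; beyond the scatter), comes from methyl in place of hydrogen on a saturated chain carbon bound to a carbonyl carbon and two saturated chain carbons, so a larger ester group went with a lower number in this assay.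

Compound 3 `CCC(C)(CC)C(=O)O[C@H]1C[C@@H](C)C=C2C=C[C@H](C)[C@H](CC[C@@H]3C[C@@H](O)CC(=O)O3)C21` is not yet measured. It differs from compound 2 by 1-ethyl-1-methylpropyl in place of tert-butyl on a carbonyl carbon; cut one bond further out, this reads (tert-butyl)carbonyl to (1-ethyl-1-methylpropyl)carbonyl. Among the measured compounds shown here, the only step that bears on it is the one from compound 1 to compound 2, which again enlarged the same ester group and lowered the number modestly. Whether a further enlargement keeps lowering the number cannot be read from two compounds, so the expectation for compound 3 is a small lowering or no step beyond the scatter in this assay; the estimate corresponds to a step of a 1.2-fold lower number from compound 2 to compound 3 (0.07 log units; within the scatter). Compound 3 is therefore expected at 2.3 nM, with a range from 0.9 nM to 6 nM.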

Compound 3, half-maximal inhibitory concentration: 1.4 nM
Compound 3: middle estimate off by 1.6-fold (0.22 log units), on the high side; the range from low to high includes it.
By their numbers in this assay, from the lowest: compounds 3 and 2 (each within the scatter of the next); then compound 1.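

At this position, on a carbonyl carbon whose other neighbours are oxygen next to a carbonyl group, 1-ethyl-1-methylpropyl in place of tert-butyl gives a 1.9-fold lower number from compound 2 to compound 3 (0.29 log units; within the scatter) in this assay, so the further enlargement is accepted, but it does not separate the two compounds. Measured from the smaller end of the series, 1-ethyl-1-methylpropyl in place of isopropyl gives a 5.5-fold lower number from compound 1 to compound 3 (0.74 log units; beyond the scatter), which shows that the isopropyl ester stands apart from both larger groups, and none of the three compounds goes against a lower number with a larger group, though the last step cannot carry that trend alone. Nothing measured on these compounds offers an explanation for these steps.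

Still open, as far as these compounds go, is whether the number stays in this region with a longer chain, such as a propyl or butyl arm in place of an ethyl arm on the same carbon, or whether it rises again past some size. A cyclohexyl ring, an amine or a carboxylic acid at the same place would show whether anything beyond a plain branched chain is accepted there.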